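This account rests on a few compounds, and the source may have more. Where it says the series, first, only, none or still open, it means among the compounds named here.

Measured in an ADME assay on MDBK cells (Bos taurus) for cytotoxicity, read by MTT assay, with a stated time of 96 h; on this read-out higher numbers stand for lower toxicity in this test and lower numbers for higher toxicity in this test:
compound 1 `O=C(CCl)Nc1ccc(-c2nc3cc(C(F)(F)F)ccc3[nH]2)cc1`: 17000 nM
compound 2 `CC(=O)Nc1ccc(-c2nc3cc(C(F)(F)F)ccc3[nH]2)cc1`: 50000 nM
compound 3 `Oc1ccc(-c2nc3cc(C(F)(F)F)ccc3[nH]2)cc1`: 51000 nM

Compound 3 carries the highest number of the three, but it lies within the scatter of compound 2 a 1.0-fold higher number from compound 2 to compound 3 (0.01 log units; within the scatter), so no order can be read between those two; only compound 1 sits apart a 3.0-fold higher number from compound 1 to compound 3 (0.48 log units; beyond the scatter), and the remaining step, a 2.9-fold higher number from compound 1 to compound 2 (0.47 log units; beyond the scatter), points the same way.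

Compound 4 `O=C(O)CCC(=O)Nc1ccc(-c2nc3cc(C(F)(F)F)ccc3[nH]2)cc1` is compound 3 with ((2-carboxyethyl)carbonyl)amino in place of hydroxy on an aromatic carbon. The step bearing most directly on this change is the pair of compound 2 and compound 3, where acetamido against hydroxy on the same aromatic carbon gave a 1.0-fold higher number from compound 2 to compound 3 (0.01 log units; within the scatter), nothing beyond the scatter. Both larger steps in the set run to compound 1 and involve the chloro on the saturated chain carbon, which compound 4 does not have. An amide with the ((2-carboxyethyl)carbonyl)amino chain is therefore expected to land close to compound 3, with the step of a 1.0-fold lower number from compound 3 to compound 4 (0.01 log units; within the scatter) expected to stay within the scatter. For compound 4 the estimate in this assay is 50000 nM, range 25000 nM to 100000 nM.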

Compound 4, half-maximal cytotoxic concentration: > 100000 nM
Compound 4: only a limit was reported (the forecaster's own chance of this, stated with the estimate: 15%); at least 2.0-fold (0.30 log units) between middle value and limit.
By their numbers in this assay, from the lowest: compound 1; then compounds 2 and 3 (each within the scatter of the next). At a limit, above all of these: compound 4.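

In this assay compound 4 gives > 100000 nM, which is a limit of the assay and not a number: the limit of > 100000 nM in this assay, at which 1 of the 4 values shown sits. Even at its floor, the step of an at least 5.8-fold higher number from compound 1 to compound 4 (0.76 log units; beyond the scatter) lies beyond the scatter, with carboxymethyl in place of chloro on the saturated chain carbon bound to a carbonyl carbon. The other two steps, an at least 1.9-fold higher number from compound 3 to compound 4 (0.29 log units; that floor lies within the scatter) and an at least 2.0-fold higher number from compound 2 to compound 4 (0.30 log units; that floor lies within the scatter), have floors within the scatter, so the aromatic carbon para to a large group takes the ((2-carboxyethyl)carbonyl)amino chain with no drop in the number, but any real rise over hydroxy or acetamido stays unproven.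

From the compounds shown here alone, how far compound 4 truly lies from compound 2 and compound 3 remains open. Also open, going by these compounds, is whether the terminal carboxylic acid or the chain itself matters, a question that a methyl ester or an amine at the chain end would address.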